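Adding a Second Hydroxy Group to a Curcumin-like Scaffold

The compounds below may be only part of what the source reports. "The series", "measured", "known", "first", "only" and "open" are said of these compounds alone.

Of the compounds shown here, three have been measured in a functional assay, with a stated time of 30 min; on this read-out lower numbers stand for stronger inhibition and higher numbers for weaker inhibition. Compound 1 `O=C(/C=C/c1ccc(O)c(O)c1)CC(=O)/C=C/c1cc(O)ccc1O` gives 60000 nM, compound 2 `O=C(/C=C/c1cccc(O)c1)CC(=O)/C=C/c1cc(O)ccc1O` gives 88000 nM, and compound 3 `O=C(/C=C/c1cccc(O)c1)CC(=O)c1ccc(O)c(O)c1` gives 10000 nM, the lowest number of the three and beyond the scatter from both others. The difference between the core of compound 2 and the core of compound 3 is not broken down here.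

Compound 1 differs from compound 2 by one change, (hydroxy in place of hydrogen on an aromatic carbon), and that change gave a 1.5-fold lower number from compound 2 to compound 1 (0.17 log units; within the scatter). The unmeasured compound 4 `O=C(/C=C/c1cc(O)ccc1O)CC(=O)c1ccc(O)c(O)c1` differs from compound 3 by the same kind of change, (hydroxy in place of hydrogen on an aromatic carbon), though the surroundings are not identical: in compound 4 the new group sits ortho to a large group and para to a hydroxy group, whereas in compound 1 it sits ortho to a hydroxy group and para to a large group.

Because the earlier step of a 1.5-fold lower number from compound 2 to compound 1 (0.17 log units; within the scatter) stayed within the scatter, a similarly small step is expected from compound 3 to compound 4 in this assay, namely a 1.3-fold lower number from compound 3 to compound 4 (0.10 log units; within the scatter). Compound 4 is therefore estimated at 8000 nM, with a likely range from 3000 nM to 25000 nM.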

Compound 4, half-maximal inhibitory concentration: 82000 nM
Compound 4: the middle estimate sits 10-fold (1.01 log units) below what was measured; measured number outside the range, above it.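

In this assay, putting a hydroxy group in place of hydrogen on the aromatic carbon of compound 3 gave an 8.2-fold higher number from compound 3 to compound 4 (0.91 log units; beyond the scatter), so inhibition became weaker on this core. This change therefore did not carry over with the same size from one core to the other: the same change on two cores in this assay, a 1.5-fold lower number (0.17 log units; within the scatter) from compound 2 to compound 1 and an 8.2-fold higher number (0.91 log units; beyond the scatter) from compound 3 to compound 4, 12-fold (1.08 log units) apart, beyond the scatter of two such steps

The comparison does not show why, since the two steps differ both in the core and in where the new hydroxy group sits, which in compound 4 is ortho to a large group and para to a hydroxy group, and a single pair on each core cannot separate these two differences.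

The compounds shown leave open whether the weaker inhibition belongs to the hydroxy group itself or would also come with another group at that place, such as a methoxy group or a fluorine atom. They also leave open what a hydroxy group would do on the core of compound 3 at the place it holds in compound 1.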